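The source may hold more compounds than are shown below. What is called first, only, known or untested is meant among the compounds shown, and "the series" means these compounds.

Working notes on the series. Three amides on a shared core differ only in the aryl group on the amide nitrogen. In an assay on HEK293 cells for binding affinity to Neuropeptide Y receptor type 5 (Homo sapiens), read by radioligand binding (a higher number here means a weaker inhibitor, a lower number a stronger inhibitor), compound 1 `Cc1cc(C(=O)Nc2cc(Cl)cc(Cl)c2)nn1-c1cccc(C(F)(F)F)c1` gives 150 nM. In this assay compound 2 `Cc1cc(C(=O)Nc2cccc(Cl)c2)nn1-c1cccc(C(F)(F)F)c1` gives 520 nM, and compound 3 `Cc1cc(C(=O)Nc2cccc(Br)c2)nn1-c1cccc(C(F)(F)F)c1` gives 359 nM. Compound 3 thus stands second highest of the three numbers: the step of a 2.4-fold higher number from compound 1 to compound 3 (0.38 log units; beyond the scatter) is modest but beyond the scatter, as is a 3.5-fold higher number from compound 1 to compound 2 (0.54 log units; beyond the scatter), whereas a 1.4-fold lower number from compound 2 to compound 3 (0.16 log units; within the scatter) stays within the scatter. Compound 4 `Cc1cc(C(=O)Nc2cccc(OC(F)(F)F)c2)nn1-c1cccc(C(F)(F)F)c1` differs from compound 3 by trifluoromethoxy in place of bromo on an aromatic carbon. Among the measured compounds shown here, no measured step tests this exact exchange; the only change at that position, a 1.4-fold lower number from compound 2 to compound 3 (0.16 log units; within the scatter), was within the scatter, so a step of at most modest size, in no firm direction, is expected in this assay. Compound 4 is estimated at 400 nM, range 150 nM to 1100 nM. The expected step is a 1.1-fold higher number from compound 3 to compound 4 (0.05 log units; within the scatter).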

Compound 4, half-maximal inhibitory concentration: 431 nM
Compound 4: the middle estimate sits 1.1-fold (0.03 log units) below what was measured; measured number inside the range.
By their numbers in this assay, from the lowest: compound 1; then compounds 3, 4 and 2 (each within the scatter of the next).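

In this assay, trifluoromethoxy on this aromatic carbon cannot be told apart from bromo (a 1.2-fold higher number from compound 3 to compound 4 (0.08 log units; within the scatter)) or from chloro (a 1.2-fold lower number from compound 2 to compound 4 (0.08 log units; within the scatter)). Even with 5 heavy atoms in place of 1, and a hydrogen-bond acceptor where bromo and chloro have none, the exchange leaves the number within the scatter, so these three single substituents are not separated at this position. Nothing available explains this lack of separation. Still open, from the compounds shown here alone, is whether an amine or a carboxylic acid here would shift the number. Among the compounds shown here, also open is whether compound 1, the only compound with its steps to the others beyond the scatter, owes that to the second chloro alone.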